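Cytotoxicity notes on a benzamide series

This account rests on a few compounds, and the source may have more. Where it says the series, first, only, none or still open, it means among the compounds named here.

Measured so far:
Compound 1, `CC(C)(C)OC(=O)N(Cc1ccco1)C(=O)c1ccc(CN2Cc3ccccc3S2(=O)=O)cc1` — in an ADME assay on RAW264.7 cells (Mus musculus) for cytotoxicity, read by WST assay (a lower number here means that less compound is tolerated, a higher number that more compound is tolerated), compound 1 gives > 100000 nM, a limit of the assay.
Compound 2, `CC(C)(C)OC(=O)N(Cc1ccco1)C(=O)c1ccc(CN2C(=O)c3ccccc3C2=O)cc1` — in this assay compound 2 gives > 100000 nM, also a limit of the assay.

For the measured compounds named here, compound 2 stands at the limit of this assay; the one further value shown, for compound 1, is a limit as well, so the step that the two limits leave unreadable from compound 1 to compound 2 cannot be read. The evidence is summarised by the limit of > 100000 nM in this assay, at which 2 of the 2 values shown sit.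

Compound 3, `CC(C)(C)OC(=O)N(Cc1ccco1)C(=O)c1ccc(Cn2sc3ccccc3c2=O)cc1`, has not yet been measured. It differs from compound 2 in that (a group of 10 heavy atoms (7 carbon, 1 nitrogen, 1 oxygen, 1 sulfur; one five-membered aromatic ring with 2 hetero atoms, one six-membered aromatic ring of carbon only) in place of a group of 11 heavy atoms (8 carbon, 1 nitrogen, 2 oxygen; one five-membered non-aromatic ring with 1 hetero atom, one six-membered aromatic ring of carbon only), on a saturated chain carbon bound to an aromatic carbon). The group that enters is aromatic in its five-membered ring and carries one fewer oxygen than the group that leaves.

No measured step bears on this change: the only step shown, from compound 1 to compound 2, is unreadable because both ends sit at the limit. Going by the values given here, no direction and no size of step can therefore be expected; the working assumption is that compound 3 also shows no toxicity within the range of this assay. The step of a number no higher from compound 2 to compound 3 (the limit leaves the size open) is thus expected to be essentially nil, and compound 3 is estimated at 100000 nM, within 40000 nM to 300000 nM, most likely again reported only as a limit.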

Compound 3, concentration lethal to 50% of the cells: > 100000 nM
Compound 3 was reported as a limit; the forecaster's own chance of this, stated with the estimate: 75%; the middle value lies on the limit itself.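

No step can be read among compound 1, compound 2 and compound 3, as all three values are limits of the assay: the limit of > 100000 nM in this assay, at which 3 of the 3 values shown sit.

The compounds shown leave open whether any group on a saturated chain carbon bound to an aromatic carbon would bring cytotoxicity within the measurable range of this assay and, if so, at what concentration.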